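The source may report more compounds than this note shows. Statements on the series, on what has been measured and on what is new or still open speak of the compounds shown alone.

Measured compounds in an assay on CHO cells for displacement of a labelled ligand from histamine receptor H3 (Macaca mulatta), read by scintillation counting, with a stated time of 1 h; a lower number here means a stronger inhibitor, a higher number a weaker inhibitor:

compound 1 `Cc1cc(N2CCC(N3CCCC3C)C2)ccc1NC(=O)NC1CCCCC1` — compound 1 gives 4.6 nM
compound 2 `Cc1cc(NC(=O)NC2CCCCC2)ccc1N1CCC(N2CCCC2C)C1` — compound 2 gives 11.2 nM
compound 3 `Cc1cc(N2CCC(N3CCCC3C)C2)ccc1NC(=O)N1CCN(C)CC1` — compound 3 gives 10.5 nM

Compounds 1 and 3 share a core and differ in one place, (4-methylpiperazin-1-yl in place of cyclohexylamino on a carbonyl carbon). That change gave a 2.3-fold higher number from compound 1 to compound 3 (0.36 log units; beyond the scatter) in this assay. Compound 2 is built from the same atoms as compound 1 but joined differently; the difference between the two cores is not broken down here. Against compound 2, compound 3 reads within the scatter, while compound 1 sits at a number beyond the scatter below compound 2.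

Compound 4 `Cc1cc(NC(=O)N2CCN(C)CC2)ccc1N1CCC(N2CCCC2C)C1` has not yet been measured. It is the counterpart of compound 3 on the core of compound 2: 4-methylpiperazin-1-yl in place of cyclohexylamino on a carbonyl carbon. The place line reads the same word for word, so this is the same change already seen once. Within the data shown here, its only precedent is the step from compound 1 to compound 3, so the expectation for compound 4 is a step of about a 2.2-fold higher number from compound 2 to compound 4 (0.35 log units; beyond the scatter) in this assay, resting on a 2.3-fold higher number from compound 1 to compound 3 (0.36 log units; beyond the scatter). Compound 4 is therefore expected to give roughly 25 nM, estimated between 11 nM and 55 nM.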

Compound 4, inhibition constant: 12.7 nM
Compound 4: the middle estimate sits 2.0-fold (0.29 log units) above what was measured, and the stated range covers the measured number.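

In this assay, 4-methylpiperazin-1-yl in place of cyclohexylamino on a carbonyl carbon gives a 1.1-fold higher number from compound 2 to compound 4 (0.05 log units; within the scatter). Set beside the earlier case of this change, the two steps cannot be told apart: the same change on two cores in this assay, a 2.3-fold higher number (0.36 log units; beyond the scatter) from compound 1 to compound 3 and a 1.1-fold higher number (0.05 log units; within the scatter) from compound 2 to compound 4, 2.0-fold (0.30 log units) apart, within the scatter of two such steps. The two cores are therefore compatible with a single shared effect of this change, but one step lies beyond the scatter and the other within it, so two pairs establish neither a fixed step size nor any dependence on the core.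

Only this one replacement is shown, so it remains open whether morpholin-4-yl or an open-chain dimethylamino group on the same carbonyl carbon would read alike on both cores. Also open, going by these compounds, is whether the change would carry over to any core beyond these two, or hold in any read-out other than this assay.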